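The compounds below may be only part of what the source reports. "The series", "measured", "known", "first", "only" and "open" are said of these compounds alone.

Working notes on the series: in a functional assay, read by spectrophotometry, tested at 100 uM (on this read-out lower numbers stand for stronger inhibition and higher numbers for weaker inhibition), compound 1 `Cc1ccc(/C=C/C(=O)c2cccc(NC(=O)c3cc(-c4ccncc4)n[nH]3)c2)cc1` gives 64600 nM and compound 2 `O=C(/C=C/c1ccc(F)cc1)c1cccc(NC(=O)c2cc(-c3ccncc3)n[nH]2)c1` gives 58700 nM, so compound 2 stands level with its only neighbour. Compound 3 `COc1ccc(/C=C/C(=O)c2cccc(NC(=O)c3cc(-c4ccncc4)n[nH]3)c2)cc1` carries methoxy in place of fluoro on an aromatic carbon, para to a large group: methoxy in place of fluoro on an aromatic carbon. Among the compounds with values here, one measured step bears on this place, fluoro in place of methyl, a 1.1-fold lower number from compound 1 to compound 2 (0.04 log units; within the scatter). Within the data shown here, with only that small step as a guide, no shift beyond the scatter is expected in this assay, and the expected step is a 1.0-fold higher number from compound 2 to compound 3 (0.01 log units; within the scatter). For compound 3 the estimated value is 60000 nM, with an expected range of 30000 nM to 110000 nM.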

Compound 3, half-maximal inhibitory concentration: 54600 nM
For compound 3 the middle estimate is 1.1-fold (0.04 log units) above the measured one, within the range that was stated.
By their numbers in this assay, from the lowest: compounds 3, 2 and 1 (each within the scatter of the next).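

In this assay methoxy in place of fluoro on this aromatic carbon gives a 1.1-fold lower number from compound 2 to compound 3 (0.03 log units; within the scatter) and methoxy in place of methyl gives a 1.2-fold lower number from compound 1 to compound 3 (0.07 log units; within the scatter) as its reading. A third group at this place, one with a hydrogen-bond acceptor where fluoro has none counted, therefore still leaves compounds 1, 2 and 3 level with one another. Nothing at hand accounts for this flat read-out.

From the compounds shown here alone, whether an amine or a carboxylic acid at this place would also stay level remains open. So does whether a change elsewhere on the shared core would move the number beyond the scatter.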